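Swapping Chloro for Methoxy on an Adenosine Receptor Binder

This account rests on a few compounds, and the source may have more. Where it says the series, first, only, none or still open, it means among the compounds named here.

Of the compounds shown here, three sharing one core have been measured in an assay on CHO cells for displacement of a labelled ligand from adenosine receptor A1 (Homo sapiens), read by scintillation counting, with a stated time of 90 min; a higher number here means a weaker inhibitor, a lower number a stronger inhibitor. Compound 1 `O=C(CCCc1ccccc1)Nc1nc2ccccc2c(=O)s1` gives 2500 nM. Compound 2 `O=C(C/C=C/c1cccc(Cl)c1)Nc1nc2ccccc2c(=O)s1` gives 562 nM. Compound 3 `Cc1ccc2nc(NC(=O)CCCc3ccccc3)sc(=O)c2c1` gives 1000 nM. Compound 2 has the lowest number of the three, but compound 3 sits within the usual scatter of it, so the two cannot be ranked; only compound 1 stands clearly apart, with a higher number.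

Compound 4 `COc1cccc(/C=C/CC(=O)Nc2nc3ccccc3c(=O)s2)c1` is not yet measured. It differs from compound 2 in one place: methoxy in place of chloro on an aromatic carbon. The change sits on the outer phenyl ring, on an aromatic carbon meta to a large group.

Within the data shown here, the one step measured so far, a 2.5-fold lower number from compound 1 to compound 3 (0.40 log units; beyond the scatter), concerns a methyl added to the core rather than any change on the outer ring, so it tells little about the present swap. Among the measured compounds shown here, no measured pair shows what replacing a chloro by a methoxy does here. With only that to go on, the expected step in this assay from compound 2 to compound 4 is small, a 1.4-fold higher number from compound 2 to compound 4 (0.15 log units; within the scatter), and may well fall within the scatter. Compound 4 is therefore estimated at 800 nM, with a likely range from 300 nM to 2500 nM.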

Compound 4, inhibition constant: 500 nM
Compound 4: middle estimate off by 1.6-fold (0.20 log units), on the high side; the range from low to high includes it.
By their numbers in this assay, from the lowest: compounds 4, 2 and 3 (each within the scatter of the next); then compound 1.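

In this assay the swap from 3-chlorophenyl to 3-methoxyphenyl comes out as a 1.1-fold lower number from compound 2 to compound 4 (0.05 log units; within the scatter) and leaves the two compounds impossible to tell apart. Among these compounds, this is the first measured change on the outer ring, and it shows that this aromatic carbon can carry a methoxy, with two heavy atoms and one hydrogen-bond acceptor, in place of a chloro, with one heavy atom and no acceptor, without a measurable shift in the inhibition constant. No measurement at hand says why the two groups read alike, so this remains a plain observation about one pair of compounds.

On these data alone, two groups at one place say little about what else this carbon would tolerate, so it stays open whether an amine, a carboxylic acid or a fluoro there would read the same. Also open, as far as these compounds go, is whether the chloro and methoxy would still read alike on a compound that also carries the methyl seen on the core of compound 3.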